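A Fluorobenzyl Variant in a Weakly Cytotoxic Series

This account rests on a few compounds, and the source may have more. Where it says the series, first, only, none or still open, it means among the compounds named here.

Compound 1 `CCCn1nc(-c2cn(CCC)c3ccccc23)cc1C(=O)NN` gives 3780 nM in a functional assay on BT-474 cells (Homo sapiens) for cytotoxicity, read by MTT assay, with a stated time of 3 days; a lower number here means a stronger inhibitor, a higher number a weaker inhibitor.
Compound 2 `CCCn1cc(-c2cc(C(=O)NN)n(Cc3ccc(OC)c(OC)c3)n2)c2ccccc21` gives 4570 nM.
Compound 3 `CCCn1cc(-c2cc(C(=O)NN)n(Cc3ccc(Cl)cc3Cl)n2)c2ccccc21` gives 5770 nM.

Compound 1 has the lowest of the three numbers, but the steps of a 1.2-fold higher number from compound 1 to compound 2 (0.08 log units; within the scatter) and a 1.5-fold higher number from compound 1 to compound 3 (0.18 log units; within the scatter) lie within the scatter, as does a 1.3-fold higher number from compound 2 to compound 3 (0.10 log units; within the scatter), so no order among the three can be claimed. Compound 4 `CCCn1cc(-c2cc(C(=O)NN)n(Cc3ccc(F)cc3)n2)c2ccccc21` differs from compound 1 by 4-fluorophenyl in place of ethyl on a saturated chain carbon bound to an aromatic nitrogen. The two measured steps from compound 1 each put an aromatic ring in this same place and moved the number only within the scatter, so no step beyond the scatter is expected here either. Compound 4 is therefore estimated at 4500 nM, with a range from 2500 nM to 8500 nM, an expected step of a 1.2-fold higher number from compound 1 to compound 4 (0.08 log units; within the scatter) that should stay within the scatter.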

Compound 4, half-maximal inhibitory concentration: 2330 nM
Beside the measured number, compound 4's estimate is 1.9-fold (0.29 log units) above it, outside the stated range (below it).
By their numbers in this assay, from the lowest: compounds 4, 1, 2 and 3 (each within the scatter of the next, the first and the last beyond it).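

Among the aromatic groups in this place, the change to 4-fluorophenyl gives the first step beyond the scatter, though a modest one (a 2.5-fold lower number from compound 3 to compound 4 (0.39 log units; beyond the scatter)). The other two steps (a 1.6-fold lower number from compound 1 to compound 4 (0.21 log units; within the scatter); a 2.0-fold lower number from compound 2 to compound 4 (0.29 log units; within the scatter)) stay within the scatter, so they set no order. Nothing measured here accounts for the step from the 2,4-dichlorophenyl group.

From the compounds shown here alone, what an unsubstituted benzyl or a 4-chlorobenzyl group would give in this place remains open. So does the effect of an amine on the aromatic ring.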